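The compounds below may be only part of what the source reports. "The series", "measured", "known", "first", "only" and "open" are said of these compounds alone.

Measured compounds in a functional assay on PANC-1 cells (Homo sapiens) for inhibition, read by MTT assay, with a stated time of 24 h; a higher number here means a weaker inhibitor, a lower number a stronger inhibitor:
- compound 1 `CC1(C)[C@H]2CC[C@]1(C)N(Cc1cn(-c3ccccc3O)nn1)C(=O)C2`: 230 nM
- compound 2 `COc1ccccc1-n1cc(CN2C(=O)C[C@@H]3CC[C@@]2(C)C3(C)C)nn1`: 120 nM
- compound 3 `Cc1ccc(-n2cc(CN3C(=O)C[C@@H]4CC[C@@]3(C)C4(C)C)nn2)cc1`: 270 nM

All three share one core and differ only in the aryl on the nitrogen of the triazole. Compound 3, carrying 4-methylphenyl, gives the highest number of the three in this assay; its step from compound 1 is within the scatter a 1.2-fold higher number from compound 1 to compound 3 (0.07 log units; within the scatter), while the step from compound 2 is beyond it, though modest a 2.3-fold higher number from compound 2 to compound 3 (0.35 log units; beyond the scatter). Between compound 1 and compound 2 the change is within the scatter a 1.9-fold lower number from compound 1 to compound 2 (0.28 log units; within the scatter).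

Compound 4 `CC1(C)[C@H]2CC[C@]1(C)N(Cc1cn(-c3ccccc3Br)nn1)C(=O)C2` is not yet measured. Its change from compound 3: 2-bromophenyl in place of 4-methylphenyl on an aromatic nitrogen. Going by the values given here, no measured step shows bromine on this ring, so the estimate rests on the two aryl exchanges already seen, both of which are small: the 2-hydroxyphenyl and 2-methoxyphenyl compounds give numbers at or somewhat under that of compound 3. A step from compound 3 to compound 4 of no more than modest size, and if anything toward a lower number, is therefore expected a 1.5-fold lower number from compound 3 to compound 4 (0.18 log units; within the scatter). Compound 4 is estimated at 180 nM in this assay, with a likely range of 80 nM to 400 nM.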

Compound 4, half-maximal inhibitory concentration: 280 nM
Beside the measured number, compound 4's estimate is 1.6-fold (0.19 log units) below it; the range from low to high includes it.
By their numbers in this assay, from the lowest: compounds 2, 1, 3 and 4 (each within the scatter of the next, the first and the last beyond it).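

In this assay, the series now includes a halogen on the aryl group, and 2-bromophenyl in place of 4-methylphenyl on the aromatic nitrogen gives a step within the scatter (a 1.0-fold higher number from compound 3 to compound 4 (0.02 log units; within the scatter)); bromo in place of hydroxy on the aromatic carbon also stays within it (a 1.2-fold higher number from compound 1 to compound 4 (0.09 log units; within the scatter)). Bromo in place of methoxy is the only new step beyond the scatter, and it is modest (a 2.3-fold higher number from compound 2 to compound 4 (0.37 log units; beyond the scatter)), so compound 2 now stands apart from both compound 3 and compound 4, although it remains within the scatter of compound 1. Nothing available explains why these steps fall as they do.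

From the compounds shown here alone, it remains open whether the separation of compound 2 belongs to methoxy alone or would extend to an ethoxy or longer alkoxy chain, an amine or a carboxylic acid on the same aromatic carbon. 4-methylphenyl and 2-bromophenyl differ in both group and place on the ring. 2-methylphenyl and 4-bromophenyl would be needed to read the effect of the group apart from that of its place.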